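Swapping the propyl for a pyrimidine ring on the amide nitrogen

The source may report more compounds than this note shows. Statements on the series, on what has been measured and on what is new or still open speak of the compounds shown alone.

Compound 1 `CCC(C)N(Cc1cccs1)C(=O)COc1ccc(C)cc1`: 2000 nM
Compound 2 `Cc1ccc(OCC(=O)N(Cc2cccs2)c2nccs2)cc1`: 2240 nM
Compound 3 `CCCN(Cc1cccs1)C(=O)COc1ccc(C)cc1`: 40 nM

All three share one core and differ only in the group on the amide-type nitrogen, tested in an assay on HEK293 cells for agonist activity at transient receptor potential cation channel subfamily M member 8 (Homo sapiens), read by fluorescence and calcium flux, with a stated time of 15 min; on this read-out higher numbers stand for an effect only at larger amounts of compound and lower numbers for an effect already at smaller amounts. Compound 3 stands lowest of the three: a 50-fold lower number from compound 1 to compound 3 (1.70 log units; beyond the scatter) and a 56-fold lower number from compound 2 to compound 3 (1.75 log units; beyond the scatter), both beyond the scatter. Compound 4 `Cc1ccc(OCC(=O)N(Cc2cccs2)c2ncccn2)cc1` carries the change (pyrimidin-2-yl in place of propyl on an amide-type nitrogen). The step from compound 2 to compound 3 bears on this most directly: there propyl took the place of 1,3-thiazol-2-yl on the same nitrogen and the number fell by a 56-fold lower number from compound 2 to compound 3 (1.75 log units; beyond the scatter). Putting another aromatic ring with hetero atoms back in place of propyl, a large rise is expected for compound 4, a 50-fold higher number from compound 3 to compound 4 (1.70 log units; beyond the scatter). Compound 4 is estimated at 2000 nM, between 400 nM and 10000 nM.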

Compound 4, half-maximal effective concentration: 3700 nM
Estimate against measurement, compound 4: 1.9-fold (0.27 log units) below; the range from low to high includes it.
By their numbers in this assay, from the lowest: compound 3; then compounds 1, 2 and 4 (each within the scatter of the next).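

Pyrimidin-2-yl in place of propyl on the amide-type nitrogen gives a 93-fold higher number from compound 3 to compound 4 (1.97 log units; beyond the scatter). Against the other two groups, the change gives a 1.7-fold higher number from compound 2 to compound 4 (0.22 log units; within the scatter) and a 1.9-fold higher number from compound 1 to compound 4 (0.27 log units; within the scatter), so 1,3-thiazol-2-yl, sec-butyl and pyrimidin-2-yl cannot be told apart, and only propyl stands apart among these four groups. No measurement shown explains this difference.

From the compounds shown here alone, whether an ethyl, a butyl or a longer straight chain would keep the low number of compound 3 remains open. So does the effect of a phenyl ring, which has no nitrogen in the ring, at this position.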